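The source may hold more compounds than are shown below. What is called first, only, known or untested is meant among the compounds shown, and "the series" means these compounds.

Among the measured compounds shown here, compound 2 `Cc1cc(C)c(-c2ncc[nH]2)cc1NC(=O)c1ccc(OCc2ccccn2)cc1` gives 3.1 in a physicochemical assay for lipophilicity (a higher number here means a more lipophilic compound, a lower number a more polar compound), and this is the only value in the set that is reported as a plain number. Compound 1 `Cc1cc(Cl)c(-c2ncc[nH]2)cc1NC(=O)c1ccc(OCc2ccccn2)cc1` is reported in this assay only as a limit of > 3. For the measured compounds named here, the one measured step, a step that the limit leaves unreadable from compound 1 to compound 2, therefore cannot be read in size, because the limit of > 3 in this assay, at which 1 of the 2 values shown sits, governs one of its two endpoints.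

Compound 3 `Cc1cc(C)c(-c2c[nH]nc2C)cc1NC(=O)c1ccc(OCc2ccccn2)cc1` is not yet measured and differs from compound 2 in a different place: 3-methyl-1H-pyrazol-4-yl in place of 1H-imidazol-2-yl on an aromatic carbon. Going by the values given here, no measured step touches the five-membered ring, so nothing in the measured data bears directly on this change, and the only measured step, a step that the limit leaves unreadable from compound 1 to compound 2, concerns a substituent elsewhere and is in any case unreadable. Without a comparable precedent, the step of a number 0.20 log units higher from compound 2 to compound 3 (within the scatter) is expected to be small, at or near the usual scatter of this assay, and if anything slightly upward. Compound 3 is accordingly estimated at 3.3 in this assay, with a range from 2.9 to 3.7.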

Compound 3, distribution coefficient: > 3
Compound 3: only a limit was reported; the forecaster's own chance of this, stated with the estimate: 30%; the middle value does not contradict the limit.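

Compound 3 is reported in this assay only as a limit, > 3. The step from compound 2 to compound 3 therefore cannot be read in size, because one of its endpoints is not a number: the limit of > 3 in this assay, at which 2 of the 3 values shown sit. The compounds shown leave open whether either single change, at the chloro position or at the five-membered ring, shifts the result in this assay at all.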